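The compounds below may be only part of what the source reports. "The series", "measured", "known", "first", "only" and "open" are said of these compounds alone.

Measured so far:
- compound 1, `COc1ccc(/C=C/C2CC(=O)C=CO2)cc1OC`, 145 uM in a functional assay on 786-0 cells (Homo sapiens) for inhibition, read by sulforhodamine B assay, with a stated time of 48 h; on this read-out lower numbers stand for stronger inhibition of growth and higher numbers for weaker inhibition of growth
- compound 2, `COc1cc(/C=C/C2CC(=O)C=CO2)cc(OC)c1OC`, 125 uM in this assay
- compound 3, `COc1ccc(/C=C/C2CC=CC(=O)O2)cc1OC`, 10.9 uM in this assay

Compounds 1 and 2 share one core and differ by methoxy in place of hydrogen on an aromatic carbon. That step gives a 1.2-fold lower number from compound 1 to compound 2 (0.06 log units; within the scatter), so the two values cannot be told apart.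

Compound 3 carries the other core. The difference between the two cores is not broken down here. In this assay compound 3 gives the lowest number of the three; compound 2 stands nearest to it and compound 1 furthest, both beyond the scatter.

Compound 4, `COc1cc(OC)c(OC)cc1/C=C/C1CC=CC(=O)O1`, is not yet measured. It differs from compound 3 by methoxy in place of hydrogen on an aromatic carbon. This is the same kind of change as from compound 1 to compound 2, but the surroundings are not the same: in compound 2 the entering methoxy is ortho to a methoxy group and meta to the group of 9 heavy atoms, whereas in compound 4 it is ortho to the group of 9 heavy atoms, meta to a methoxy group and para to a methoxy group.

Among the measured compounds shown here, the only precedent for adding a methoxy, in compound 1 and compound 2, stayed within the scatter, so the expected step for compound 4 in this assay is a 1.1-fold lower number from compound 3 to compound 4 (0.04 log units; within the scatter). On that basis compound 4 is estimated at 10 uM, with a likely range from 4 uM to 30 uM.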

Compound 4, concentration for growth inhibition (reported as GI): 6 uM
Estimate against measurement, compound 4: 1.7-fold (0.22 log units) above, and the stated range covers the measured number.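

On the core of compound 3, methoxy in place of hydrogen on an aromatic carbon gives a 1.8-fold lower number from compound 3 to compound 4 (0.26 log units; within the scatter) in this assay, so the two values cannot be told apart. Set beside the same change on the core of compound 1, the step shows no detectable difference from one core to the other: the same change on two cores in this assay, a 1.2-fold lower number (0.06 log units; within the scatter) from compound 1 to compound 2 and a 1.8-fold lower number (0.26 log units; within the scatter) from compound 3 to compound 4, 1.6-fold (0.19 log units) apart, within the scatter of two such steps. This supports only a narrow reading, that adding this methoxy left the number within the scatter on both cores; it does not establish a rule for other cores or positions, and the surroundings also differ, with the entering methoxy in compound 4 ortho to a group of 9 heavy atoms, meta to a methoxy group and para to a methoxy group.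

The compounds shown leave open how the series responds on the aromatic ring to anything other than methoxy, such as an amine, a carboxylic acid or a longer chain in place of a methoxy group. They also leave open which single structural change accounts for the difference in numbers seen with the two cores, and whether the methoxy groups are needed at all.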